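The source may report more compounds than this note shows. Statements on the series, on what has been measured and on what is new or still open speak of the compounds shown alone.

Compound 1 `N#CC1CN1C(=O)Nc1ccc(Cl)c(Cl)c1`: 14000 nM
Compound 2 `CCCCNC(=O)N1CC1C#N`: 18000 nM
Compound 3 `N#CC1CN1C(=O)Nc1ccc(F)cc1`: 9000 nM

In a functional assay on WiDr cells (Homo sapiens) for inhibition (a higher number here means a weaker inhibitor, a lower number a stronger inhibitor), compound 3 gives the lowest of the three numbers, but its gaps to compound 1 and to compound 2 both lie within the usual scatter, so the three values tell no order. Compound 4 `N#CC1CN1C(=O)Nc1ccccc1` differs from compound 3 in one place: hydrogen in place of fluoro on an aromatic carbon. Among the measured compounds shown here, no measured pair here shows such a step, so its size is unknown from these data. The expectation is a small step from compound 3 to compound 4, of about a 1.3-fold higher number from compound 3 to compound 4 (0.12 log units; within the scatter), not clearly beyond the scatter in either direction. Compound 4 is therefore estimated at 12000 nM in this assay, within a range of 5000 nM to 30000 nM.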

Compound 4, half-maximal inhibitory concentration: 12000 nM
Estimate against measurement, compound 4: no gap at the digits printed; the measured number falls inside the stated range.
By their numbers in this assay, from the lowest: compounds 3, 4, 1 and 2 (each within the scatter of the next).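

In this assay, hydrogen in place of fluoro on the aromatic carbon para to a group of 8 heavy atoms gives a 1.3-fold higher number from compound 3 to compound 4 (0.12 log units; within the scatter). Among the compounds shown here, this is the first pair in the set that differs in only one place, and at this position the two compounds cannot be told apart, so the fluoro group shows no measurable contribution here. No other measurement shown bears on this result. From the compounds shown here alone, whether an amine or a methoxy group on this same carbon would move the number clearly beyond the scatter remains open.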